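A few compounds are considered here, and "the series" means these few. Any claim that something is new, unique, unknown or untested is made for them only; others in the source may bear on it.

Measured compounds:
compound 1, `COc1cccc(C2=CC(c3ccc(Cl)cc3)NC(=S)N2)c1`, 150 nM
compound 2, `COc1cccc(C2=CC(c3ccc(Br)cc3)NC(=S)N2)c1`, 135 nM
compound 3, `COc1cccc(C2=NNC(c3ccc(Cl)cc3)C2O)c1`, 49 nM

These three compounds were tested in a functional assay on MCF7 cells (Homo sapiens) for antiproliferative activity, read by sulforhodamine B assay, with a stated time of 48 h; a lower number here means a stronger inhibitor, a higher number a weaker inhibitor. Compound 1 and compound 2 share one core, and compound 3 has a different core; the difference between the two cores is not broken down here. Compound 4, `COc1cccc(C2=NNC(c3ccc(Br)cc3)C2O)c1`, has not yet been measured. It differs from compound 3 by bromo in place of chloro on an aromatic carbon. The same change has already been made once, from compound 1 to compound 2, where it reads (bromo in place of chloro on an aromatic carbon). That step gave a 1.1-fold lower number from compound 1 to compound 2 (0.05 log units; within the scatter), so on the first core the swap made essentially no difference. Because the same change gave a 1.1-fold lower number from compound 1 to compound 2 (0.05 log units; within the scatter) on the first core and the places of the two changes are the same word for word, the change from compound 3 to compound 4 is treated as the same change, and a step of similar size is expected, which is a 1.1-fold lower number from compound 3 to compound 4 (0.04 log units; within the scatter). Going by the values given here, this rests on the single earlier step and on the value of compound 3 in this assay, which is 49 nM. Compound 4 is therefore expected to give about 45 nM, with a likely range from 25 nM to 90 nM.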

Compound 4, half-maximal inhibitory concentration: 49 nM
For compound 4 the middle estimate is 1.1-fold (0.04 log units) below the measured one, and the stated range covers the measured number.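

In this assay, the swap from 4-chlorophenyl to 4-bromophenyl gives no change at the digits printed from compound 3 to compound 4 (within the scatter). Set beside the earlier step on the other core, the swap carries over between the two cores in this series, with neither step showing a real effect: the same change on two cores in this assay, a 1.1-fold lower number (0.05 log units; within the scatter) from compound 1 to compound 2 and no change at the digits printed (within the scatter) from compound 3 to compound 4, 1.1-fold (0.05 log units) apart, within the scatter of two such steps This shows only that one small swap, which leaves the number within the scatter on both cores, reads alike on these two cores; it does not show that a change with a larger effect would carry over in the same way, and it does not explain why chloro and bromo read alike here.

The compounds shown hold only chloro or bromo at this place, so what an amine, a carboxylic acid or a longer carbon chain would do there remains open. From the compounds shown here alone, the rest of each core stays the same across each pair, so the effect of changes elsewhere, and whether this swap reads alike on other cell lines, also remains open.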